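The compounds below may be only part of what the source reports. "The series", "measured", "known", "first", "only" and "open" are said of these compounds alone.

Working notes on a small coumarin-free description of the series: all four members share one core, shown for compound 1 as `COc1cc2ccc(=O)oc2cc1OCC(=O)c1ccccc1`. In a functional assay on HUVEC cells (Homo sapiens) for inhibition, read by MTT assay, with a stated time of 24 h, tested at 10 uM (on this read-out higher numbers stand for more inhibition of growth at the one concentration tested and lower numbers for less inhibition of growth), compound 1 gives 3.4%. Compound 2, `COc1cc2ccc(=O)oc2cc1OCC(O)CN1CCCCC1`, carries a hydroxy-bearing chain ending in a piperidine; in this assay compound 2 gives 31.4%. Compound 3, `COc1cc2ccc(=O)oc2cc1OCCCCBr`, ends its chain in a bromine; in this assay compound 3 gives 11.2%. For the measured compounds named here, on the numbers so far compound 3 sits second highest of the three: its nearest neighbour is compound 1, lower by an amount within the scatter, so the two cannot be ordered; its furthest is compound 2, higher by an amount beyond the scatter.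

Compound 4, `COc1cc2ccc(=O)oc2cc1OCC(O)CNC(C)C`, has not yet been measured in this assay. It differs from compound 3 as follows: 1-hydroxy-2-(isopropylamino)ethyl in place of 3-bromopropyl on a saturated chain carbon bound to an oxygen on an aromatic ring. Going by the values given here, no step between two measured compounds matches this change. The closest guide is compound 2, whose chain likewise carries a hydroxyl and an amine and which gives 31.4% in this assay. On that basis a step upward beyond the scatter is expected from compound 3 to compound 4, estimated at a number 12.8 percentage points higher from compound 3 to compound 4 (beyond the scatter). Compound 4 is therefore expected to give about 24% in this assay, within a range from 8% to 40%.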

Compound 4, percent growth inhibition at one concentration: 0.1%
For compound 4 the middle estimate is 23.9 percentage points above the measured one, and the stated range ends above it.
By their numbers in this assay, from the lowest: compounds 4, 1 and 3 (each within the scatter of the next, the first and the last beyond it); then compound 2.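

In this assay, a chain carrying both a hydroxyl and an amine does not by itself go with more inhibition of growth: 1-hydroxy-2-(isopropylamino)ethyl in place of 3-bromopropyl gives a number 11.1 percentage points lower from compound 3 to compound 4 (beyond the scatter), the opposite direction to what compound 2 alone suggested. With the hydroxy-bearing chain held fixed, isopropylamino in place of piperidin-1-yl gives a number 31.3 percentage points lower from compound 2 to compound 4 (beyond the scatter), so across this pair the higher number goes with piperidin-1-yl and not with the hydroxyl and amine the two compounds share, and compound 4 stands against any reading that credits the shared chain alone. No data at hand account for either step.

As far as these compounds go, whether a morpholine or a pyrrolidine in place of isopropylamino would give a number nearer that of compound 2 or that of compound 4 remains open. Also open, from the compounds shown here alone, is whether piperidin-1-yl on a plain butyl chain, without the hydroxyl, would keep the number seen for compound 2 in this assay.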